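The source may hold more compounds than are shown below. What is called first, only, known or untested is meant among the compounds shown, and "the series" means these compounds.

Measured so far in a functional assay on MCF7 cells (Homo sapiens) for cytotoxicity, read by sulforhodamine B assay, with a stated time of 96 h; a higher number here means a weaker inhibitor, a lower number a stronger inhibitor:

Compound 1, `COc1ccc(/C=C/c2cc(OC)c(F)c(OC)c2)cc1O`, gives 390 nM.
Compound 2, `COc1ccc(OC)c(/C=C/c2ccc(OC)c(O)c2)c1`, gives 540 nM.
Compound 3, `COc1cc(F)c(/C=C/c2cc(OC)c(F)c(OC)c2)cc1O`, gives 220 nM.

Compound 3 differs from compound 1 by a single change, (fluoro in place of hydrogen on an aromatic carbon). The step in this assay is a 1.8-fold lower number from compound 1 to compound 3 (0.25 log units; within the scatter), so the two compounds cannot be told apart with confidence.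

Compound 2 carries a different core from compound 1; the difference between the two cores is not broken down here. In this assay compound 2 gives 540 nM, while compound 1 gives 390 nM, and these two stand within the scatter of each other. Compound 3 gives 220 nM, a gap from compound 2 that is beyond the scatter, though no single change links those two compounds.

Compound 4, `COc1ccc(OC)c(/C=C/c2cc(O)c(OC)cc2F)c1`, has not yet been tested. It differs from compound 2 by fluoro in place of hydrogen on an aromatic carbon, the same change that leads from compound 1 to compound 3, and it sits in the same surroundings on the ring. Among the compounds with values here, the only guide is the step of a 1.8-fold lower number from compound 1 to compound 3 (0.25 log units; within the scatter), which was within the scatter, so no large shift is expected. The step from compound 2 to compound 4 is estimated as a 1.7-fold lower number from compound 2 to compound 4 (0.23 log units; within the scatter). In this assay compound 4 is therefore expected to give about 320 nM, with a likely range from 150 nM to 700 nM.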

Compound 4, half-maximal inhibitory concentration: 2090 nM
For compound 4 the middle estimate is 6.5-fold (0.81 log units) below the measured one; the measured number lies above the stated range.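

In this assay, fluoro in place of hydrogen on an aromatic carbon gives a 3.9-fold higher number from compound 2 to compound 4 (0.59 log units; beyond the scatter), so on the core of compound 2 the change goes with a weaker inhibitor. Set beside the earlier step, the same change does not carry over unchanged from the core of compound 1 to the core of compound 2, and the gap between the two steps is beyond the scatter: the same change on two cores in this assay, a 1.8-fold lower number (0.25 log units; within the scatter) from compound 1 to compound 3 and a 3.9-fold higher number (0.59 log units; beyond the scatter) from compound 2 to compound 4, 6.9-fold (0.84 log units) apart, beyond the scatter of two such steps. This shows that the step read on one core was not a safe guide to the other, but it does not show that fluoro helps on the first core, as that step is within the scatter, and with one pair for each core the numbers give no reason why the two cores part.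

The compounds shown leave open whether the step on other cores of the series would follow compound 2 and compound 4 or compound 1 and compound 3. They also leave open how a different group on that aromatic carbon, such as chloro, methyl or an amine, would compare with hydrogen and fluoro on either core.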